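Furan for benzofuran on a nucleoside core: a predicted step

A few compounds are considered here, and "the series" means these few. Any claim that something is new, unique, unknown or untested is made for them only; others in the source may bear on it.

Measured compounds:
- compound 1 `Nc1nc2c(c(-c3ccco3)cn2[C@@H]2O[C@H](CO)[C@@H](O)[C@H]2O)c(=O)[nH]1`: in a functional assay on HCT-116 cells (Homo sapiens), read by MTT assay, with a stated time of 72 h (on this read-out lower numbers stand for stronger inhibition and higher numbers for weaker inhibition), compound 1 gives > 20000 nM, which is a limit of the assay and not a number.
- compound 2 `Nc1nc2c(c(-c3cc4ccccc4o3)cn2[C@@H]2O[C@H](CO)[C@@H](O)[C@H]2O)c(=O)[nH]1`: in this assay compound 2 gives > 100000 nM, again a limit and not a number.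
- compound 3 `Nc1nc(N)c2c(-c3cc4ccccc4o3)cn([C@@H]3O[C@H](CO)[C@@H](O)[C@H]3O)c2n1`: in this assay compound 3 gives 14000 nM, the only number among the three.

The cores of compound 2 and compound 3 differ, but that difference is not broken down here. Compound 1 and compound 2 share one core and differ only by furan-2-yl in place of 1-benzofuran-2-yl on an aromatic carbon. The size of that step, a step that the two limits leave unreadable from compound 2 to compound 1, cannot be read because the limit of > 100000 nM in this assay, at which 1 of the 3 values shown sits, and the limit of > 20000 nM in this assay, at which 1 of the 3 values shown sits, close off both ends of it.

Compound 4 `Nc1nc(N)c2c(-c3ccco3)cn([C@@H]3O[C@H](CO)[C@@H](O)[C@H]3O)c2n1` is not yet measured. It stands to compound 3 as compound 1 stands to compound 2: the change is furan-2-yl in place of 1-benzofuran-2-yl on an aromatic carbon, the same change at the same place, word for word.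

Since the measured pair gives no readable size, the expectation for compound 4 rests mainly on compound 3, which gives 14000 nM. The step from compound 3 to compound 4 is estimated as a 1.4-fold higher number from compound 3 to compound 4 (0.15 log units; within the scatter), a shift small enough to sit within the usual scatter, with a real chance that only a limit is returned. Compound 4 is therefore expected to give about 20000 nM, with a likely range from 7000 nM to 60000 nM.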

Compound 4, half-maximal inhibitory concentration: > 20000 nM
Compound 4 was reported as a limit; the forecaster's own chance of this, stated with the estimate: 35%; the middle value lies on the limit itself.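

Furan-2-yl in place of 1-benzofuran-2-yl now gives an at least 1.4-fold higher number from compound 3 to compound 4 (0.15 log units; that floor lies within the scatter), which fixes only a floor for the step and not its true size. In this assay compound 4 gives > 20000 nM, a limit of the assay and not a number, so the step may be small or far larger, and the floor is all that can be said: the limit of > 20000 nM in this assay, at which 2 of the 4 values shown sit. The same change on the core shared by compound 1 and compound 2 cannot be read, so there is no size to set beside this floor, and the results show neither that the change carries from one core to the other nor that it fails to.

As far as these compounds go, all four compounds carry either furan-2-yl or 1-benzofuran-2-yl on this aromatic carbon, and compound 3 alone gives a true number, so the reach of the series at this place stays open. From the compounds shown here alone, how an amine or a longer carbon chain at the same place would read out, on either core, remains unknown, and a value inside the measurable range on both cores would be needed before the change could be compared at all.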